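The compounds below may be only part of what the source reports. "The series", "measured", "known", "first", "only" and "open" are said of these compounds alone.

Measured so far in this series:
compound 1 `COc1ccc(Nc2cncc(N3CC4CC(C3)N4)c2)cc1` — 2.2 nM
compound 2 `Oc1ccc(Nc2cncc(N3CC4CC(C3)N4)c2)cc1` — 0.988 nM
compound 3 `Fc1ccc(Nc2cncc(N3CC4CC(C3)N4)c2)cc1` — 1.25 nM

All three share one core and differ only in the group on the outer aromatic ring. In an assay on HEK293 cells for displacement of a labelled ligand from Neuronal acetylcholine receptor; alpha3/beta4 (Homo sapiens) (a lower number here means a stronger inhibitor, a higher number a weaker inhibitor), compound 3 lies within the scatter of both others, since a 1.3-fold higher number from compound 2 to compound 3 (0.10 log units; within the scatter) and a 1.8-fold lower number from compound 1 to compound 3 (0.25 log units; within the scatter) are both small; only the change a 2.2-fold lower number from compound 1 to compound 2 (0.35 log units; beyond the scatter) reaches beyond the scatter. Compound 4 `c1ccc(Nc2cncc(N3CC4CC(C3)N4)c2)cc1` continues this exchange with hydrogen in place of fluoro on an aromatic carbon. Because a 1.3-fold higher number from compound 2 to compound 3 (0.10 log units; within the scatter) and a 1.8-fold lower number from compound 1 to compound 3 (0.25 log units; within the scatter) both stayed within the scatter, the step of a 1.2-fold higher number from compound 3 to compound 4 (0.08 log units; within the scatter) is also expected to stay within the scatter, in either direction. The inhibition constant of compound 4 is therefore estimated at 1.5 nM, with a likely range from 0.6 nM to 4 nM.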

Compound 4, inhibition constant: 0.799 nM
Compound 4: the middle estimate sits 1.9-fold (0.27 log units) above what was measured; the measured number falls inside the stated range.
By their numbers in this assay, from the lowest: compounds 4, 2, 3 and 1 (each within the scatter of the next, the first and the last beyond it).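

With the substituent gone altogether, the ring loses nothing measurable against fluoro, a 1.6-fold lower number from compound 3 to compound 4 (0.19 log units; within the scatter), or against hydroxy, a 1.2-fold lower number from compound 2 to compound 4 (0.09 log units; within the scatter), so in this assay neither group is needed at this position. Only methoxy stands apart from the bare phenyl, a 2.8-fold lower number from compound 1 to compound 4 (0.44 log units; beyond the scatter), and that step is modest. Nothing available gives a reason for this. On these data alone, what an amine, a carboxylic acid or a longer chain such as butoxy would do in this place stays open, as does whether methoxy's gap recurs with ethoxy.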